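Indole Carboxylic Acid in Place of Benzofuran

A few compounds are considered here, and "the series" means these few. Any claim that something is new, unique, unknown or untested is made for them only; others in the source may bear on it.

Of the compounds shown here, three sharing one core have been measured in a functional assay on DU-145 cells (Homo sapiens) for inhibition, read by trypan blue exclusion, with a stated time of 72 h; a lower number here means a stronger inhibitor, a higher number a weaker inhibitor. Compound 1 `Cn1c(=O)c(S(=O)(=O)c2ccc(F)cc2F)cc2cnc(Nc3ccc4cc[nH]c4c3)nc21` gives 5000 nM, compound 2 `Cn1c(=O)c(S(=O)(=O)c2ccc(F)cc2F)cc2cnc(Nc3cccc4[nH]ccc34)nc21` gives 750 nM, and compound 3 `Cn1c(=O)c(S(=O)(=O)c2ccc(F)cc2F)cc2cnc(Nc3ccc4occc4c3)nc21` gives 15000 nM. Compound 3 stands at the highest number of the three: the step of a 3.0-fold higher number from compound 1 to compound 3 (0.48 log units; beyond the scatter) is modest, and the step of a 20-fold higher number from compound 2 to compound 3 (1.30 log units; beyond the scatter) is large.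

Compound 4 `Cn1c(=O)c(S(=O)(=O)c2ccc(F)cc2F)cc2cnc(Nc3ccc4[nH]c(C(=O)O)cc4c3)nc21` differs from compound 3 in one place: 2-carboxy-1H-indol-5-yl in place of 1-benzofuran-5-yl on a nitrogen on an aromatic ring. Among the compounds with values here, the steps that bear on this change are those that swap the benzofuran for an indole on the same nitrogen. Within the data shown here, both run toward lower numbers in this assay, but the indole in compound 4 carries a carboxy group that none of the measured compounds has, and its attachment differs from both compound 1 and compound 2. The step from compound 3 to compound 4 is therefore expected to be a 3.0-fold lower number from compound 3 to compound 4 (0.48 log units; beyond the scatter), toward a lower number, with wide uncertainty. Compound 4 is estimated at 5000 nM, within a range from 1000 nM to 30000 nM.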

Compound 4, half-maximal inhibitory concentration: 10000 nM
The estimate for compound 4 lay 2.0-fold (0.30 log units) below the measured number, within the range that was stated.
By their numbers in this assay, from the lowest: compound 2; then compounds 1, 4 and 3 (each within the scatter of the next, the first and the last beyond it).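

In this assay the change to 2-carboxy-1H-indol-5-yl from 1-benzofuran-5-yl on this nitrogen gives a 1.5-fold lower number from compound 3 to compound 4 (0.18 log units; within the scatter) and does not separate the two groups, whereas the earlier indoles had both stood apart from the benzofuran. The step of a 2.0-fold higher number from compound 1 to compound 4 (0.30 log units; within the scatter) likewise does not separate the two indoles, while a 13-fold higher number from compound 2 to compound 4 (1.12 log units; beyond the scatter) shows that an indole on this nitrogen does not by itself reach the level of compound 2. Nothing at hand accounts for these differences.

On these data alone, the carboxy group and the point of attachment change together in compound 4, so the share of each remains unknown. Also open, as far as these compounds go, are what a plain 1H-indol-5-yl would give, and whether a methyl ester or a primary amide in place of the carboxylic acid would move the number.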